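The compounds below may be only part of what the source reports. "The series", "measured", "known", "first", "only" and "open" are said of these compounds alone.

Measured so far:
- compound 1, `COC(=O)c1ccc2c(ccn2-c2cccc(NC(=O)Nc3ccc(Cl)c(C(F)(F)F)c3)c2)n1`: 9500 nM
- compound 2, `O=C(Nc1ccc(-n2ccc3nc(C(=O)NCc4ccccc4)ccc32)cc1)Nc1cccc(C(F)(F)F)c1`: 7900 nM

In a functional assay on A375P cells (Homo sapiens) for cytotoxicity, read by MTT assay (on this read-out lower numbers stand for stronger inhibition and higher numbers for weaker inhibition), compound 1 gives the higher of the two numbers, and compound 2 gives 7900 nM; the gap between these two values lies within the scatter, so the two compounds cannot be told apart on these data.

The next step in the series is compound 3, `COC(=O)c1ccc2c(ccn2-c2cccc(NC(=O)Nc3cccc(C(F)(F)F)c3)c2)n1`, not yet measured. It differs from compound 1 in one place: hydrogen in place of chloro on an aromatic carbon. Going by the values given here, no step between two measured compounds speaks to this change, so the expectation rests only on the two values shown. The shared core of compound 1 is kept; only the chloro is gone. A modest weakening, beyond the scatter but small, is expected for the step of a 1.7-fold higher number from compound 1 to compound 3 (0.23 log units; within the scatter). On that basis compound 3 is estimated at 16000 nM, with a range from 6000 nM to 45000 nM.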

Compound 3, half-maximal inhibitory concentration: > 10000 nM
Compound 3 ended at the assay's limit; the forecaster's own chance of this, stated with the estimate: 15%; the middle value is on the limit's open side.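

In this assay compound 3 gives > 10000 nM, which is a limit of the assay and not a number. Going by these compounds alone, the change from 4-chloro-3-(trifluoromethyl)phenyl to 3-(trifluoromethyl)phenyl, on the carbon ortho to a trifluoromethyl group, therefore reads only as a floor: an at least 1.0-fold higher number from compound 1 to compound 3 (0.02 log units; that floor lies within the scatter), so hydrogen in place of chloro gives a first direct read on this position, but no size for the step and no proof of a real loss. This reading is bounded by the top of the measurable range: the limit of > 10000 nM in this assay, at which 1 of the 3 values shown sits.

From the compounds shown here alone, whether removing chloro costs anything beyond the scatter remains open. So does the outcome with other groups on this carbon, such as fluoro, a methoxy group or an amine.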